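Alkenyl extension of the methoxy group in the series

The compounds below may be only part of what the source reports. "The series", "measured", "known", "first", "only" and "open" are said of these compounds alone.

Compound 1 `COC1(c2ccc(Br)cc2)SC=C(C)n2c1noc2=O` is tested in a functional assay on A2780/DX3 cells (Homo sapiens) for antiproliferative activity, read by MTT assay, with a stated time of 3 days; on this read-out lower numbers stand for stronger inhibition and higher numbers for weaker inhibition. In this assay compound 1 reaches only the limit of the measurement, > 100000 nM. Compound 2 `COC1(c2ccc(Cl)cc2)SC=C(C)n2c1noc2=O` gives 113000 nM in this assay. Compound 3 `O=c1onc2n1C=CSC2(O)c1ccc(Cl)cc1` also reaches only a limit in this assay, > 100000 nM. Among the measured compounds shown here, the one step joining measured compounds, a step that the limit leaves unreadable from compound 1 to compound 2, cannot be sized. Two of the three values sit at the limit, (the limit of > 100000 nM in this assay, at which 2 of the 3 values shown sit), so compound 1 stands at the weak end of what the measurement can report, with no readable step leading away from it.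

Compound 4 `CC/C=C/COC1(c2ccc(Br)cc2)SC=C(C)n2c1noc2=O` differs from compound 1 by but-1-en-1-yl in place of hydrogen on a saturated chain carbon bound to an oxygen on a saturated carbon, which read one bond further out is methoxy to (pent-2-en-1-yl)oxy. For the measured compounds named here, no measured pair shows this change or one like it, so no step bears on it. The expectation for compound 4 is therefore set at the position of compound 1, meaning an expected step of a number no higher from compound 1 to compound 4 (the limit leaves the size open) not beyond the scatter. Compound 4 is expected to give 100000 nM, within 20000 nM to 500000 nM.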

Compound 4, half-maximal inhibitory concentration: 111000 nM
The estimate for compound 4 lay 1.1-fold (0.05 log units) below the measured number, within the range that was stated.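

No step can be read from compound 1 to compound 4, since the value of compound 1 is a limit: the limit of > 100000 nM in this assay, at which 2 of the 4 values shown sit.

The compounds shown leave open whether replacing methoxy with (pent-2-en-1-yl)oxy on the shared core changes antiproliferative activity at all.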